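Working notes: 3-methylazetidin-1-yl to 3,3-dimethylazetidin-1-yl

The source may hold more compounds than are shown below. What is called first, only, known or untested is meant among the compounds shown, and "the series" means these compounds.

Of the compounds shown here, two have a number so far in a physicochemical assay for solubility, measured as kinetic solubility; on this read-out lower numbers stand for lower solubility and higher numbers for higher solubility. Compound 1 (`Cc1cnc(NC(=O)c2cc(Oc3ncc(C(=O)N(C)C)cn3)c3cc(C)oc3c2)cn1`) gives 485000 nM. Compound 2 (`Cc1cc2c(Oc3cnc(C(=O)N4CC(C)C4)cn3)cc(C(=O)Nc3cnccn3)cc2o1`) gives 49000 nM, the lowest of the two numbers, and its gap to compound 1 lies beyond the scatter. These two compounds differ in more than one place, so their gap cannot be tied to any single change.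

Compound 3 (`Cc1cc2c(Oc3cnc(C(=O)N4CC(C)(C)C4)cn3)cc(C(=O)Nc3cnccn3)cc2o1`) differs from compound 2 in one place: 3-methylazetidin-1-yl becomes 3,3-dimethylazetidin-1-yl, with methyl in place of hydrogen on a saturated ring carbon. For the measured compounds named here, no measured pair shows a change of this kind, so the expectation starts from compound 2 at 49000 nM and from the small size of the change. The expected move, a 1.4-fold lower number from compound 2 to compound 3 (0.15 log units; within the scatter), is a slight one towards lower numbers in this assay, not beyond the scatter at its middle, although the uncertainty is wide. For compound 3 the estimated value is 35000 nM, with an expected range of 12000 nM to 90000 nM.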

Compound 3, solubility: 78000 nM
Compound 3: the middle estimate sits 2.2-fold (0.35 log units) below what was measured; the range from low to high includes it.
By their numbers in this assay, from the lowest: compounds 2 and 3 (each within the scatter of the next); then compound 1.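

Methyl in place of hydrogen on a saturated ring carbon, two ring bonds from the ring nitrogen, gives the first single-place reading in the series: in this assay the step is a 1.6-fold higher number from compound 2 to compound 3 (0.20 log units; within the scatter) and compound 2 and compound 3 cannot be told apart on this read-out. At this ring carbon of the four-membered non-aromatic ring, 3-methylazetidin-1-yl and 3,3-dimethylazetidin-1-yl are therefore equivalent within the scatter, but this is one step and sets no general pattern for the series, while the gap to compound 1 stays unassigned, since compound 1 differs from both in more than one place. No measured property is available that bears on this step.

Open, as far as these compounds go, is whether a hydroxyl group, a fluorine atom or an amine on the same ring carbon would give a step beyond the scatter, or whether only methyl reads this way. Also open, from the compounds shown here alone, is whether a larger saturated ring in place of the azetidine, such as pyrrolidine or morpholine, would keep the reading of compound 2 in this assay.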